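This account rests on a few compounds, and the source may have more. Where it says the series, first, only, none or still open, it means among the compounds named here.

Of the compounds shown here, three built on one shared core have been tested in a physicochemical assay for solubility, in phosphate buffer, measured as kinetic solubility, at pH 7.4; on this read-out lower numbers stand for lower solubility and higher numbers for higher solubility. Compound 1 `Cc1oc(-c2c(Cl)cccc2Br)nc1CN1CCC(C(=O)NCCCN2C[C@H](C)C[C@H](C)C2)CC1` carries a 2-bromo-6-chlorophenyl group on an aromatic carbon of a five-membered aromatic ring with 1 nitrogen and 1 oxygen. In this assay compound 1 gives > 83 ug/mL, which is a limit of the assay. Compound 2 `Cc1cccc(Cl)c1-c1nc(CN2CCC(C(=O)NCCCN3CCC(C)(C)CC3)CC2)c(C)o1` gives > 74 ug/mL in this assay, also a limit. Compound 3 `Cc1ccccc1-c1nc(CN2CCC(C(=O)N3CCN(CCN(C)C)CC3)CC2)c(C)o1` gives > 67 ug/mL in this assay, again a limit. Going by the values given here, compound 1 therefore stands at a limit, as do the two companions, and no measured step between them can be drawn.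

Compound 4 `COc1cccc(OC)c1-c1nc(CN2CCC(C(=O)NCCCN3C[C@H](C)C[C@H](C)C3)CC2)c(C)o1` has not yet been measured in this assay. It differs from compound 1 in one place: 2,6-dimethoxyphenyl in place of 2-bromo-6-chlorophenyl on an aromatic carbon. Among the compounds with values here, with no measured step to lean on, the change is expected to be a step that the limit leaves unreadable from compound 1 to compound 4, a step estimated to stay within the usual scatter. Compound 4 is expected to give about 90 ug/mL in this assay, with an estimated range from 45 ug/mL to 200 ug/mL.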

Compound 4, solubility: > 76 ug/mL
Compound 4 ended at the assay's limit; the forecaster's own chance of this, stated with the estimate: 75%; the middle value does not contradict the limit.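

Compound 1 and compound 4 both stand at a limit in this assay, so no step can be read for 2,6-dimethoxyphenyl in place of 2-bromo-6-chlorophenyl. The compounds shown leave open what actual number each would give, so no group on the shared core can yet be tied to a change in this assay.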